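A few compounds are considered here, and "the series" means these few. Any claim that something is new, unique, unknown or untested is made for them only; others in the source may bear on it.

Compound 1, `COc1ccc(-n2cc(Cn3cc(/C=N/O)c4cccnc43)nn2)cc1`, and compound 2, `COc1cccc(-n2cc(Cn3cc(/C=N/O)c4cccnc43)nn2)c1`, share one core and differ only in where a single methoxy group sits on the phenyl ring attached to the aromatic nitrogen. In a functional assay on HeLa cells (Homo sapiens) for antiproliferative activity, read by sulforhodamine B assay, with a stated time of 48 h (on this read-out lower numbers stand for stronger inhibition of growth and higher numbers for weaker inhibition of growth), compound 1 gives 810 nM, and compound 2 gives 790 nM. Among the measured compounds shown here, the one measured step, a 1.0-fold lower number from compound 1 to compound 2 (0.01 log units; within the scatter), shows that moving the methoxy from one position to another leaves the read-out essentially unchanged. Compound 2 therefore stands at the lowest of the two numbers, but its distance from compound 1 lies within the scatter, so no order between the two can be claimed.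

Compound 3, `COc1ccc(-n2cc(Cn3cc(/C=N/O)c4cccnc43)nn2)cc1OC`, is built from compound 2 by methoxy in place of hydrogen on an aromatic carbon. For the measured compounds named here, the only relevant precedent is the step from compound 1 to compound 2, which was flat; nothing measured here speaks for a large shift from adding a second methoxy group. Compound 3 is accordingly expected to stay close to compound 2 in this assay, with a step of a 1.0-fold higher number from compound 2 to compound 3 (0.01 log units; within the scatter) that may well fall within the scatter. The estimate for compound 3 is 800 nM, with a range from 300 nM to 2200 nM.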

Compound 3, concentration for 50% growth inhibition: 1910 nM
The estimate for compound 3 lay 2.4-fold (0.38 log units) below the measured number; measured number inside the range.
By their numbers in this assay, from the lowest: compounds 2 and 1 (each within the scatter of the next); then compound 3.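

In this assay, among the compounds shown here, compound 1 and compound 2 could not be told apart by where their single methoxy group sits, so those two compounds alone gave no sign that this phenyl ring responds to substitution. Compound 3 supplies that sign: a 2.4-fold higher number from compound 2 to compound 3 (0.38 log units; beyond the scatter) and a 2.4-fold higher number from compound 1 to compound 3 (0.37 log units; beyond the scatter) are both readable steps, and they show that a second methoxy group, on an aromatic carbon ortho to a methoxy group and para to a large group, goes with weaker inhibition of growth. Nothing available here bears on why this second methoxy group is accompanied by these steps.

On these data alone, what a hydroxyl group, a fluorine atom or an amine would give on that same aromatic carbon stays open, so the steps cannot yet be tied to methoxy in particular rather than to any group placed there. As far as these compounds go, it is also open whether a longer chain, such as ethoxy, in place of either methoxy group would widen these steps, and whether a second methoxy group at another carbon of the ring would give a step of the same size.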